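This account rests on a few compounds, and the source may have more. Where it says the series, first, only, none or still open, it means among the compounds named here.

Measured in a functional assay on GC3/MTK- cells (Homo sapiens) for inhibition; a higher number here means a weaker inhibitor, a lower number a stronger inhibitor:
Compound 1 `C#CCN(Cc1ccc2nc(C)nc(O)c2c1)c1ccc(C#N)cc1`: 5000 nM
Compound 2 `C#CCN(Cc1ccc2nc(C)nc(O)c2c1)c1ccc(C(=O)c2ccccc2)cc1`: 6200 nM
Compound 3 `C#CCN(Cc1ccc2nc(C)nc(O)c2c1)c1ccc(S(=O)(=O)N2CCOCC2)cc1`: 5200 nM

Compound 3, at 5200 nM, cannot be separated from the other two compounds. The data show a 1.0-fold higher number from compound 1 to compound 3 (0.02 log units; within the scatter) and a 1.2-fold lower number from compound 2 to compound 3 (0.08 log units; within the scatter), and both steps lie within the scatter.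

Compound 4 `C#CCN(Cc1ccc2nc(C)nc(O)c2c1)c1ccc(S(=O)(=O)N2CCN(C)CC2)cc1` has not yet been measured. It keeps the sulfonyl group of compound 3 and carries 4-methylpiperazin-1-yl in place of morpholin-4-yl on a sulfonyl sulfur. For the measured compounds named here, no measured step covers this exchange directly. The closest evidence is the set of exchanges on the aromatic carbon that bears the sulfonyl group in compound 3. These are the two steps above and a 1.2-fold higher number from compound 1 to compound 2 (0.09 log units; within the scatter), also within the scatter. Across these three compounds, then, the group at that place has shown no measurable effect, so no step beyond the scatter is expected in this assay. The estimated step is a 1.0-fold lower number from compound 3 to compound 4 (0.02 log units; within the scatter). For compound 4 the expected value is 5000 nM, with an estimated range of 2500 nM to 10000 nM.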

Compound 4, half-maximal inhibitory concentration: > 10000 nM
Compound 4 was reported as a limit; the forecaster's own chance of this, stated with the estimate: 10%; middle value at least 2.0-fold (0.30 log units) away from the limit.
By their numbers in this assay, from the lowest: compounds 1, 3 and 2 (each within the scatter of the next). At a limit, above all of these: compound 4.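

In this assay, compound 4 is reported as > 10000 nM, which is a limit and not a number. The exchange of morpholin-4-yl for 4-methylpiperazin-1-yl on a sulfonyl sulfur gives an at least 1.9-fold higher number from compound 3 to compound 4 (0.28 log units; that floor lies within the scatter), and the comparisons with the other two groups give an at least 1.6-fold higher number from compound 2 to compound 4 (0.20 log units; that floor lies within the scatter) and an at least 2.0-fold higher number from compound 1 to compound 4 (0.30 log units; that floor lies within the scatter); unlike the earlier exchanges, which all stayed within the scatter, these steps have only floors, and no floor is beyond the scatter, so the results do not establish a real loss of inhibition. All three steps rest on a single reported limit: the limit of > 10000 nM in this assay, at which 1 of the 4 values shown sits.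

Going by these compounds, the size of the true step from compound 3 to compound 4 stays open. So does how piperazin-1-yl without the methyl, or piperidin-1-yl, would read on the same sulfonyl sulfur.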